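Pyrrolidin-1-yl for methylsulfanyl on two cores

The source may hold more compounds than are shown below. What is called first, only, known or untested is meant among the compounds shown, and "the series" means these compounds.

Compound 1 `CSc1nc(Cl)c(C(=O)c2ccccc2)s1` and compound 2 `O=C(c1ccccc1)c1sc(N2CCCC2)nc1Cl` share one core; compound 3 `COC(=O)c1sc2nc(SC)sc2c1C` and compound 4 `COC(=O)c1sc2nc(N3CCCC3)sc2c1C` share another. The difference between the two cores is not broken down here. In a functional assay on PC-3 cells (Homo sapiens) for cytotoxicity, read by MTT assay, with a stated time of 72 h (a lower number here means a stronger inhibitor, a higher number a weaker inhibitor), compound 1 gives only a limit, > 100000 nM. Compound 2 likewise gives only a limit, > 100000 nM. The step that the two limits leave unreadable from compound 1 to compound 2 is thus left without a size; the change is pyrrolidin-1-yl in place of methylsulfanyl on an aromatic carbon. In this assay, within the data shown here, compound 3 gives 90000 nM, the one number among the three values. Compound 4 carries the same kind of change, pyrrolidin-1-yl in place of methylsulfanyl on an aromatic carbon: here the place is part of a fused or bridged system of two rings, and the words on the ring atoms two ring bonds away, one bearing a chloro group and one a group of 8 heavy atoms, do not appear. What the series shows is the limit of > 100000 nM in this assay, at which 2 of the 3 values shown sit; it gives no size for the change itself. The expected step is a 1.1-fold higher number from compound 3 to compound 4 (0.05 log units; within the scatter), because compound 3 sits at 90000 nM and the measured pair gives no direction. Compound 4 is estimated at 100000 nM, between 30000 nM and 300000 nM, with a real chance that only a limit is reported.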

Compound 4, half-maximal inhibitory concentration: > 100000 nM
Compound 4 gave a limit, no number (the forecaster's own chance of this, stated with the estimate: 55%); the middle value sits exactly at the limit.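

In this assay, pyrrolidin-1-yl in place of methylsulfanyl on the core of compound 3 gives an at least 1.1-fold higher number from compound 3 to compound 4 (0.04 log units; that floor lies within the scatter). The step on the core of compound 1 cannot be read, and neither the size nor the direction of the change can be compared between the two cores, so nothing here shows that the change carries over from one core to the other. Both pyrrolidin-1-yl compounds, compound 2 and compound 4, end at the same reading, which is a limit and not a number: the limit of > 100000 nM in this assay, at which 3 of the 4 values shown sit.

Among these compounds, compound 3, at 90000 nM, holds the only number. Going by these compounds, it remains open whether anything on these cores gives a reading well clear of the limit. Also open, on these data alone, is whether a primary amine or a longer alkyl chain in place of methylsulfanyl, or a carboxylic acid on the core of compound 3, would yield a number in this assay.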